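Hydroxyalkyl chain homologation on the shared core

The source may hold more compounds than are shown below. What is called first, only, known or untested is meant among the compounds shown, and "the series" means these compounds.

Compound 3 `CC[C@H](Nc1nc(NCc2ccccn2)c2ncn(C(C)C)c2n1)C(C)O` gives 21000 nM in a functional assay on CH1 cells (Homo sapiens) for inhibition, read by sulforhodamine B assay, with a stated time of 96 h (a higher number here means a weaker inhibitor of growth, a lower number a stronger inhibitor of growth), the lower of the two numbers here, though compound 1 `CC[C@H](Nc1nc(NCc2ccccn2)c2ncn(C(C)C)c2n1)C(C)(C)O` at 42000 nM sits within the scatter of it. Compound 2 `CC[C@H](Nc1nc(NCc2ccccn2)c2ncn(C(C)C)c2n1)C(O)C(C)(C)C` reaches only the limit of > 50000 nM in this assay, at which 1 of the 3 values shown sits, in this assay, given as > 50000 nM. The step of a 2.0-fold lower number from compound 1 to compound 3 (0.30 log units; within the scatter) and the step of an at least 2.3-fold lower number from compound 2 to compound 3 (0.37 log units; beyond the scatter) are the measured steps that bear on compound 4 `CCC(O)[C@H](CC)Nc1nc(NCc2ccccn2)c2ncn(C(C)C)c2n1`, which differs from compound 3 by methyl in place of hydrogen on a saturated chain carbon, two bonds along the chain from an oxygen on a saturated carbon. Both measured steps went toward lower numbers on removing bulk beside the hydroxyl; adding a methyl one bond further out is expected to cost little, a 1.3-fold higher number from compound 3 to compound 4 (0.11 log units; within the scatter). Compound 4 is therefore estimated at 27000 nM, between 11000 nM and 60000 nM.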

Compound 4, concentration for 50% growth inhibition: 33000 nM
Compound 4: middle estimate off by 1.2-fold (0.09 log units), on the low side, within the range that was stated.
By their numbers in this assay, from the lowest: compounds 3, 4 and 1 (each within the scatter of the next). At a limit, above all of these: compound 2.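

In this assay, a methyl at this place, two bonds along the chain from an oxygen on a saturated carbon, leaves the number within the scatter, with a 1.6-fold higher number from compound 3 to compound 4 (0.20 log units; within the scatter). The 1-hydroxypropyl and 1-hydroxy-1-methylethyl groups are not separated either, with a 1.3-fold lower number from compound 1 to compound 4 (0.10 log units; within the scatter). Against compound 2 only a floor can be read, an at least 1.5-fold lower number from compound 2 to compound 4 (0.18 log units; that floor lies within the scatter), and compound 2 remains a limit: the limit of > 50000 nM in this assay, at which 1 of the 4 values shown sits.

On these data alone, whether an amine or a carboxylic acid in place of the hydroxyl, or a longer chain than 1-hydroxypropyl, would move the number beyond the scatter stays open.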